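Carboxy Side Chain on the Shared Core: an Expectation

The compounds below may be only part of what the source reports. "The series", "measured", "known", "first", "only" and "open" are said of these compounds alone.

Measured compounds:
- Compound 1, `Cn1ncc(Cl)c1-c1cc(C(=O)N[C@@H]2CN[C@H](CCn3cncn3)C[C@H]2c2ccc(Cl)c(Cl)c2)oc1Cl`: 4.47 nM
- Compound 2, `Cn1ncc(Cl)c1-c1cc(C(=O)N[C@@H]2CN[C@H](CCN3CCCCC3)C[C@H]2c2ccc(Cl)c(Cl)c2)oc1Cl`: 5.65 nM

Compound 1 and compound 2 share a core and differ only in the group at the end of the side chain. In an assay for inhibition of RAC-alpha serine/threonine-protein kinase (Homo sapiens), read by HTRF, with a stated time of 1 h (on this read-out higher numbers stand for weaker inhibition and lower numbers for stronger inhibition), compound 1 gives 4.47 nM, and compound 2 gives 5.65 nM. The step of a 1.3-fold higher number from compound 1 to compound 2 (0.10 log units; within the scatter) lies within the scatter, so the two numbers cannot be ordered. Going by the values given here, compound 2 therefore stands level with compound 1, the only other number at hand.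

Compound 3, `Cn1ncc(Cl)c1-c1cc(C(=O)N[C@@H]2CN[C@H](CC(=O)O)C[C@H]2c2ccc(Cl)c(Cl)c2)oc1Cl`, is the next compound: carboxy in place of (piperidin-1-yl)methyl on a saturated chain carbon bound to a saturated ring carbon. No measured step covers an exchange of this kind; the one step shown, a 1.3-fold higher number from compound 1 to compound 2 (0.10 log units; within the scatter), swaps one ring-bearing group for another and says little about a carboxy entering. The expectation for compound 3 is therefore wide. Compound 3 is expected to give about 15 nM in this assay, within a range of 3 nM to 80 nM, which would mean a step of a 2.7-fold higher number from compound 2 to compound 3 (0.42 log units; beyond the scatter).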

Compound 3, half-maximal inhibitory concentration: 1.94 nM
Estimate against measurement, compound 3: 7.7-fold (0.89 log units) above; the whole stated range lies above it.
By their numbers in this assay, from the lowest: compound 3; then compounds 1 and 2 (each within the scatter of the next).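

Going by these compounds alone, compounds 1 and 2 showed only that two ring-bearing end groups on this side chain could not be told apart in this assay; compound 3 shows that the ring can go altogether without any weakening of inhibition. Carboxy in place of (piperidin-1-yl)methyl gives a 2.9-fold lower number from compound 2 to compound 3 (0.46 log units; beyond the scatter) and carboxy in place of (1H-1,2,4-triazol-1-yl)methyl gives a 2.3-fold lower number from compound 1 to compound 3 (0.36 log units; beyond the scatter) so that, among these three compounds, the carboxy end stands apart from two ring-bearing ends that remain level. Nothing at hand accounts for this difference.

The compounds shown leave open whether the step belongs to the carboxy itself or to the absence of a ring, a question on which a methyl ester or a primary amide in the same place would bear. Also open, on these data alone, is how a carboxy on a longer chain, or a simple primary amine, would read.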